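The source may hold more compounds than are shown below. What is called first, only, known or untested is meant among the compounds shown, and "the series" means these compounds.

Compound 1 `COc1ccc(C(=O)NC(CCN(C)C)c2ccc(Cl)cc2)cc1`: 162%
Compound 2 `Cc1ccc(C)c(C(=O)NC(CCN(C)C)c2ccc(Cl)cc2)c1`: 164%

In an assay on NIH3T3 cells with Urotensin-2 receptor (Homo sapiens) as the target (a higher number here means a larger maximal response, a lower number a smaller maximal response), compound 2 gives 164%, and compound 1 gives a number within the scatter of it, since a number 2 percentage points higher from compound 1 to compound 2 (within the scatter). Compound 3 `Cc1ccc(C(=O)NC(CCN(C)C)c2ccc(Cl)cc2)c(C)c1` differs from compound 2 by 2,4-dimethylphenyl in place of 2,5-dimethylphenyl on a carbonyl carbon. Within the data shown here, the only measured step bearing on this also swapped one aromatic ring for another on the same carbonyl carbon, and it stayed within the scatter, so no step beyond the scatter is expected for compound 3 in this assay: a number 4 percentage points lower from compound 2 to compound 3 (within the scatter). Compound 3 is therefore estimated at 160%, with a range from 140% to 180%.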

Compound 3, largest response reached (reported as efficacy), in percent of the reference or control that the assay uses: 147%
Estimate against measurement, compound 3: 13 percentage points above; the range from low to high includes it.
By their numbers in this assay, from the lowest: compound 3; then compounds 1 and 2 (each within the scatter of the next).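

In this assay, 2,4-dimethylphenyl in place of 2,5-dimethylphenyl on the carbonyl carbon keeps the same atoms yet gives a number 17 percentage points lower from compound 2 to compound 3 (beyond the scatter), so the arrangement of the methyl groups on this ring matters here, not just their presence. The change from 4-methoxyphenyl also gives a number 15 percentage points lower from compound 1 to compound 3 (beyond the scatter), although compound 1 and compound 2 lie within the scatter of each other. No measurement shown explains this difference. From the compounds shown here alone, whether a 2,6-dimethylphenyl or 3,4-dimethylphenyl group would follow compound 2 or compound 3 remains open.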